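Trifluoromethyl on the Aromatic Ring of Compound 3

The source may report more compounds than this note shows. Statements on the series, on what has been measured and on what is new or still open speak of the compounds shown alone.

Measured compounds:
Compound 1 `CN(C)CCC(NC(=O)C#Cc1ccccc1)c1ccc(Cl)cc1` — 124%
Compound 2 `COc1ccc(/C=C/C(=O)NC(CCN(C)C)c2ccc(Cl)cc2)cc1` — 99%
Compound 3 `CN(C)CCC(NC(=O)/C=C/c1ccccc1)c1ccc(Cl)cc1` — 128%

All three were tested in a functional assay on NIH3T3 cells for agonist activity at Urotensin-2 receptor (Homo sapiens), with a stated time of 5 days; a higher number here means a larger maximal response, a lower number a smaller maximal response. Among them compound 3 shows the highest number, but its gap to compound 1, a number 4 percentage points higher from compound 1 to compound 3 (within the scatter), lies within the scatter, so the two cannot be ranked. Only compound 2 stands clearly apart: a number 29 percentage points higher from compound 2 to compound 3 (beyond the scatter) shows that removing the methoxy group raised the maximal response by a modest, real margin.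

Compound 4 `CN(C)CCC(NC(=O)/C=C/c1ccc(C(F)(F)F)cc1)c1ccc(Cl)cc1` carries a change on the same kind of position: trifluoromethyl in place of hydrogen on an aromatic carbon. Going by the values given here, the only measured step that touches a substituent on that aromatic ring is a number 29 percentage points higher from compound 2 to compound 3 (beyond the scatter), and it ran in the direction of a bare ring giving the larger response. Among the compounds with values here, that step concerned a methoxy group, not trifluoromethyl, so it is an imperfect guide, and no measured compound carries trifluoromethyl at all. A small drop seems the more likely outcome, though one within the scatter is also possible.

For compound 4 the expected value in this assay is therefore 112%, with a likely range from 88% to 136%. The step this implies, a number 16 percentage points lower from compound 3 to compound 4 (beyond the scatter), is estimated as a slight decrease.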

Compound 4, largest response reached (reported as efficacy), in percent of the reference or control that the assay uses: 133%
Compound 4: middle estimate off by 21 percentage points, on the low side; the measured number falls inside the stated range.
By their numbers in this assay, from the lowest: compound 2; then compounds 1, 3 and 4 (each within the scatter of the next).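

Adding trifluoromethyl to the aromatic ring, para to a large group, does not lower the maximal response in this assay: the reading is a number 5 percentage points higher from compound 3 to compound 4 (within the scatter) and so the larger group cannot be told apart from a bare hydrogen at this position. Swapping one substituent for another at the same place does matter, since the comparison with methoxy gives a number 34 percentage points higher from compound 2 to compound 4 (beyond the scatter) and shows that the lower response of compound 2 does not extend to every group placed here, so among these compounds only methoxy stands apart from the rest. Nothing available explains why methoxy and trifluoromethyl part ways at this position.

With only hydrogen, methoxy and trifluoromethyl shown here, it remains open whether a different group at this place, such as an amine, a carboxylic acid or a single fluorine atom, would follow methoxy or trifluoromethyl. As far as these compounds go, it is equally open whether trifluoromethyl would give a similar response on another carbon of the ring, or whether it would do so with the triple-bonded linker of compound 1 in place of the double bond.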